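A few compounds are considered here, and "the series" means these few. Any claim that something is new, unique, unknown or untested is made for them only; others in the source may bear on it.

- Compound 1 (`Cc1ccc(NC(=O)CC(CCC(=O)O)c2nnc(CCCC(C)C)n2C2CC2)c(C)c1`) gives 0.2 10^-6 cm/s
- Compound 2 (`Cc1ccc(NC(=O)C[C@H](CCC(=O)O)c2noc(-c3cc(CC(C)C)on3)c2C2CC2)c(Cl)c1`) gives 36 10^-6 cm/s

In an ADME assay on Caco-2 cells (Homo sapiens) for permeability (a lower number here means that the compound crosses the layer more slowly, a higher number that the compound crosses the layer faster), compound 2 stands higher of the two at 36 10^-6 cm/s and compound 1 gives 0.2 10^-6 cm/s in this pair. The gap between the two lies well beyond the scatter. Going by the values given here, these two differ in more than one place, so they offer no measured step for the change ahead. Compound 3 (`Cc1ccc(NC(=O)C[C@H](CCC(=O)O)c2noc(-c3ncc(CC(C)C)o3)c2C2CC2)c(Cl)c1`) carries 5-isobutyl-1,3-oxazol-2-yl in place of 5-isobutyl-1,2-oxazol-3-yl on an aromatic carbon with the same atoms joined differently. In this assay the expected result is a 1.2-fold lower number from compound 2 to compound 3 (0.08 log units; within the scatter) and no change beyond the scatter. Compound 3 is estimated at 30 10^-6 cm/s with an expected range from 12 10^-6 cm/s to 60 10^-6 cm/s on this reading.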

Compound 3, apparent permeability: 32 10^-6 cm/s
Compound 3: middle estimate off by 1.1-fold (0.03 log units), on the low side, and the stated range covers the measured number.
By their numbers in this assay, from the lowest: compound 1; then compounds 3 and 2 (each within the scatter of the next).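

Putting 5-isobutyl-1,3-oxazol-2-yl in place of 5-isobutyl-1,2-oxazol-3-yl on an aromatic carbon gives, in this assay, a 1.1-fold lower number from compound 2 to compound 3 (0.05 log units; within the scatter). This first measured step at this position shows that these two arrangements of the same atoms cannot be told apart in this read-out. No measured evidence here bears on the reason.

Going by these compounds, whether a group carrying an amine, or a longer chain in place of isobutyl, would hold the number at this position remains open. Compound 1 differs from both others in more than one place, so no single change accounts for its gap to them.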